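A Cyclopropyl Ketone Tested Against Colon Carcinoma Cells

The source may hold more compounds than are shown below. What is called first, only, known or untested is meant among the compounds shown, and "the series" means these compounds.

Compound 1 `COc1ccc(-n2c(SCC(=O)c3ccc4ccccc4c3)nnc2-c2cc(OC)c(OC)c(OC)c2)cc1`, compound 2 `COc1ccc(-n2c(SCC(=O)C3CC3)nnc2-c2cc(OC)c(OC)c(OC)c2)cc1` and compound 3 `COc1cc(-c2nnc(SCC(=O)c3ccc4ccccc4c3)n2-c2ccc(N(C)C)cc2)cc(OC)c1OC` share a core and were tested in a functional assay on HCT-116 cells (Homo sapiens) for inhibition, read by MTT assay, with a stated time of 48 h; on this read-out lower numbers stand for stronger inhibition and higher numbers for weaker inhibition. In this assay compound 1 gives > 60000 nM, which is a limit of the assay and not a number. Compound 2 gives > 60000 nM in this assay, again a limit. Compound 3 gives 54500 nM in this assay. Compound 3 differs from compound 1 by dimethylamino in place of methoxy on an aromatic carbon, and this made an at least 1.1-fold lower number from compound 1 to compound 3 (0.04 log units; that floor lies within the scatter). Compound 2 differs from compound 1 by cyclopropyl in place of naphthalen-2-yl on a carbonyl carbon, which made a step that the two limits leave unreadable from compound 1 to compound 2; the step cannot be read since (the limit of > 60000 nM in this assay, at which 2 of the 3 values shown sit).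

Compound 4 `COc1cc(-c2nnc(SCC(=O)C3CC3)n2-c2ccc(N(C)C)cc2)cc(OC)c1OC` differs from compound 3 by the same change, (cyclopropyl in place of naphthalen-2-yl on a carbonyl carbon). Going by the values given here, the one measured example of this change gives no readable size, and compound 3 itself lies close to the limit, so compound 4 is expected to show a 1.3-fold higher number from compound 3 to compound 4 (0.11 log units; within the scatter) in this assay, with a real chance that only a limit is reported. The estimate for compound 4 is 70000 nM, with a range from 35000 nM to 150000 nM.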

Compound 4, half-maximal inhibitory concentration: > 60000 nM
Compound 4: no number, only a limit; the forecaster's own chance of this, stated with the estimate: 65%; the middle value does not contradict the limit.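

In this assay, cyclopropyl in place of naphthalen-2-yl on a carbonyl carbon made an at least 1.1-fold higher number from compound 3 to compound 4 (0.04 log units; that floor lies within the scatter). Going by these compounds, compound 4 gives > 60000 nM, which is a limit of the assay and not a number, so this step is only a floor and the true size of the change remains unknown. The same change on the core of compound 1 and the step between the two cyclopropyl ketones cannot be read, so the data neither show that the change carries from one core to the other nor show that it fails to: the limit of > 60000 nM in this assay, at which 3 of the 4 values shown sit.

What the compounds shown leave open is whether another group on that carbonyl carbon, such as a primary amine, a carboxylic acid or a longer chain, would give a readable number in this assay. Also open, on these data alone, is whether diethylamino on the aromatic carbon that carries dimethylamino would give a number that stands clear of the scatter.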